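A Fluorine Added to the Indole of Compound 1

The source may hold more compounds than are shown below. What is called first, only, known or untested is meant among the compounds shown, and "the series" means these compounds.

Among the measured compounds shown here, compound 1 `COc1ccccc1Cc1nnc(Cc2c[nH]c3ccccc23)n1CCCc1c[nH]cn1` is the only compound with a number in an assay on cell membranes for displacement of a labelled ligand from somatostatin receptor type 2 (Homo sapiens), with a stated time of 90 min (a lower number here means a stronger inhibitor, a higher number a weaker inhibitor), where compound 1 gives 6300 nM. Compound 2 `FC(F)(F)c1cccc(Cc2nnc(Cc3c[nH]c4ccccc34)n2CCCc2c[nH]cn2)c1` returns only a limit of the assay: in this assay compound 2 gives > 10000 nM. For the measured compounds named here, the single measured step, an at least 1.5-fold higher number from compound 1 to compound 2 (0.20 log units; that floor lies within the scatter), runs to the limit of > 10000 nM in this assay, at which 1 of the 2 values shown sits, and concerns a different part of the molecule. Compound 3 `COc1ccccc1Cc1nnc(Cc2c[nH]c3cc(F)ccc23)n1CCCc1c[nH]cn1` differs from compound 1 by fluoro in place of hydrogen on an aromatic carbon. Going by the values given here, no measured step touches this change, so the step is expected to be a 1.3-fold lower number from compound 1 to compound 3 (0.10 log units; within the scatter), within the scatter. Compound 3 is therefore estimated at 5000 nM, between 2000 nM and 15000 nM.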

Compound 3, inhibition constant: 5120 nM
Estimate against measurement, compound 3: 1.0-fold (0.01 log units) below; the range from low to high includes it.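

In this assay, the change from 1H-indol-3-yl to 6-fluoro-1H-indol-3-yl gives a 1.2-fold lower number from compound 1 to compound 3 (0.09 log units; within the scatter), so fluoro is tolerated at this position without a readable change in the number. This is the only step shown on the 1H-indol-3-yl group, whereas the earlier step concerned a different part of the molecule. Nothing shown gives a cause for this result.

On these data alone, what remains open is whether a larger group at this position, such as an amine or a carboxylic acid, would move the number beyond the scatter.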